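A few compounds are considered here, and "the series" means these few. Any claim that something is new, unique, unknown or untested is made for them only; others in the source may bear on it.

Measured compounds in a functional assay on A549 cells (Homo sapiens) for cytotoxicity, read by MTT assay, with a stated time of 4 days; a higher number here means a weaker inhibitor, a lower number a stronger inhibitor:
Compound 1 `C=C1C[C@]23C[C@@]1(O)CC[C@H]2c1cc(Br)c(O)c(C)c1[C@@H]3Cn1cc(-c2ccccc2)nn1`: compound 1 reads > 20000 nM, a limit of this assay.
Compound 2 `C=C1C[C@]23C[C@@]1(O)CC[C@H]2c1cc(Br)c(O)c(C)c1[C@@H]3Cn1cc(-c2ccc(F)cc2)nn1`: compound 2 reads 17900 nM.
Compound 3 `C=C1C[C@]23C[C@@]1(O)CC[C@H]2c1ccc(O)c(C)c1[C@@H]3Cn1cc(-c2ccc(C)cc2)nn1`: compound 3 reads > 20000 nM, again a limit.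

Compound 3 therefore stands at the weak end, with only a limit and no number. Both compound 1 and compound 3 sit at the limit of > 20000 nM in this assay, at which 2 of the 3 values shown sit. The step to compound 4 `C=C1C[C@]23C[C@@]1(O)CC[C@H]2c1cc(Br)c(O)c(C)c1[C@@H]3Cn1cc(-c2ccc(C)cc2)nn1` is bromo in place of hydrogen on an aromatic carbon. Going by the values given here, no measured step covers this change; the only measured step, an at least 1.1-fold lower number from compound 1 to compound 2 (0.04 log units; that floor lies within the scatter), concerns a different change and lies within the scatter, and the two compounds that already carry the bromo group give no strong value. No step beyond the scatter is therefore expected in this assay. Compound 4 is estimated at 25000 nM, range 10000 nM to 60000 nM, meaning an expected step that the limit leaves unreadable from compound 3 to compound 4.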

Compound 4, half-maximal inhibitory concentration: > 20000 nM
Compound 4: only a limit was reported; the forecaster's own chance of this, stated with the estimate: 70%; the middle value does not contradict the limit.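

In this assay, bromo in place of hydrogen, ortho to the hydroxy group, does not bring compound 4 off the assay limit, and the steps from compound 3 and from compound 1 to compound 4 cannot be read. Methyl in place of fluoro gives an at least 1.1-fold higher number from compound 2 to compound 4 (0.04 log units; that floor lies within the scatter). Most of the series now sits at one limit: the limit of > 20000 nM in this assay, at which 3 of the 4 values shown sit.

From the compounds shown here alone, whether any group at this position gives a readable value stays open. An amine or a carboxylic acid in place of the bromo group of compound 4 would test this.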